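Chloro to Fluoro: What Happens to Clearance?

The source may hold more compounds than are shown below. What is called first, only, known or untested is meant among the compounds shown, and "the series" means these compounds.

compound 1 `O=C(c1cc(-c2ccc(=O)[nH]c2)on1)N1CCC(Cc2ccc(F)cc2)CC1`: 19.7 mL/min/kg
compound 2 `O=C(c1cc(-c2ccc(=O)[nH]c2)on1)N1CCC(Cc2ccc(Cl)cc2)CC1`: 5.4 mL/min/kg
compound 3 `O=C(Nc1ccc2[nH]c(=O)oc2c1)C(=O)N1CCN(c2ccc(Cl)cc2)CC1`: 7.2 mL/min/kg
compound 4 `O=C(Nc1ccc2[nH]c(=O)oc2c1)C(=O)N1CCN(c2ccc(F)cc2)CC1`: not yet measured

All three values come from an ADME assay on the whole organism (Rattus norvegicus, strain Sprague-Dawley) for pharmacokinetics, using cassette dosing, at a dose of 0.5 mg/kg by the intravenous route; on this read-out higher numbers stand for fast clearance and lower numbers for slow clearance. Compound 3, at 7.2 mL/min/kg, lies within the usual scatter of compound 2 and clearly lower than compound 1.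

Compound 4 differs from compound 3 by a single exchange: fluoro in place of chloro on an aromatic carbon. In words, this is fluoro in place of chloro on an aromatic carbon, turning the 4-chlorophenyl into 4-fluorophenyl.

Among the measured compounds shown here, only one measured step bears on this exchange, and it runs the opposite way, chloro in place of fluoro. It is a 3.6-fold lower number from compound 1 to compound 2 (0.56 log units; beyond the scatter). Read backwards, that step points to a higher number on going from chloro to fluoro, so a rise beyond the scatter is the likely outcome here. The evidence is thin, however: it is a single pair, and its core differs from the core of compound 3. The full size of that step therefore cannot simply be carried over, and a somewhat smaller change seems the safer expectation.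

The estimated change is a 2.5-fold higher number from compound 3 to compound 4 (0.40 log units; beyond the scatter).

The expected value for compound 4 is 18 mL/min/kg, within an estimated range of 9 mL/min/kg to 36 mL/min/kg.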

Compound 4, clearance: 11.1 mL/min/kg
Beside the measured number, compound 4's estimate is 1.6-fold (0.21 log units) above it; low and high end bracket the measured number.
By their numbers in this assay, from the lowest: compounds 2, 3, 4 and 1 (each within the scatter of the next, the first and the last beyond it).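

On the core of compound 3, the exchange of 4-chlorophenyl for 4-fluorophenyl in this assay gives a 1.5-fold higher number from compound 3 to compound 4 (0.19 log units; within the scatter), a step that repeated measurements of one compound could produce on their own. The earlier pair alone, a 3.6-fold lower number from compound 1 to compound 2 (0.56 log units; beyond the scatter), looked like a clear effect of this exchange, but the second core shows that a step beyond the scatter does not appear on every core. Even so, the two steps cannot be told apart from each other, so these compounds do not show that the two cores truly respond differently: the same change on two cores in this assay, a 3.6-fold lower number (0.56 log units; beyond the scatter) from compound 1 to compound 2 and a 1.5-fold lower number (0.19 log units; within the scatter) from compound 4 to compound 3, 2.4-fold (0.37 log units) apart, within the scatter of two such steps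

Only chloro and fluoro appear on this aromatic carbon, which leaves open how a bromo, a methyl or a nitrile group at the same place would read out on either core. Going by these compounds, with just two cores in view, it also stays open which of the two steps is closer to what this exchange gives on other cores, such as one where the 4-fluorophenyl group is carried on a longer chain.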